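Swapping the dimethylaminophenyl end for a chlorophenyl

The compounds below may be only part of what the source reports. "The series", "measured", "known", "first", "only" and "open" are said of these compounds alone.

Of the compounds shown here, three that share one core have been measured in an assay on isolated protein with Bile acid receptor (Homo sapiens) as the target; on this read-out higher numbers stand for an effect only at larger amounts of compound and lower numbers for an effect already at smaller amounts. Compound 1 `COC(=O)/C=C/c1cccc(N(Cc2ccc(/C=C/c3cccc(C(F)(F)F)c3)cc2)C(=O)NC(C)C)c1` gives 932 nM. Compound 2 `COC(=O)/C=C/c1cccc(N(Cc2ccc(/C=C/c3ccc(F)cc3)cc2)C(=O)NC(C)C)c1` gives 348 nM, and compound 3 `COC(=O)/C=C/c1cccc(N(Cc2ccc(-c3ccc(N(C)C)cc3)cc2)C(=O)NC(C)C)c1` gives 162 nM. Compound 3 stands lowest of the three: the step of a 5.8-fold lower number from compound 1 to compound 3 (0.76 log units; beyond the scatter) and the step of a 2.1-fold lower number from compound 2 to compound 3 (0.33 log units; beyond the scatter) both favour it, and the step of a 2.7-fold lower number from compound 1 to compound 2 (0.43 log units; beyond the scatter) separates the other two.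

Compound 4 `COC(=O)/C=C/c1cccc(N(Cc2ccc(-c3cccc(Cl)c3)cc2)C(=O)NC(C)C)c1` is the next compound to be tested. Its change from compound 3 is 3-chlorophenyl in place of 4-(dimethylamino)phenyl on an aromatic carbon. Going by the values given here, none of the measured steps makes this exact change: the two steps leading to compound 3 exchange a two-carbon chain carrying a substituted phenyl for a directly attached 4-(dimethylamino)phenyl, and the step from compound 1 to compound 2 exchanges one substituted phenyl on that chain for another. The closest guide is that the 4-(dimethylamino)phenyl of compound 3 beats both ring types tried before it, so removing it is expected to cost something, though the size is uncertain. Compound 4 is therefore expected to give about 350 nM in this assay, within a range of 100 nM to 1200 nM, an estimated step of a 2.2-fold higher number from compound 3 to compound 4 (0.33 log units; beyond the scatter).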

Compound 4, half-maximal effective concentration: 1400 nM
Estimate against measurement, compound 4: 4.0-fold (0.60 log units) below, and the stated range ends below it.
By their numbers in this assay, from the lowest: compound 3; then compound 2; then compounds 1 and 4 (each within the scatter of the next).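

In this assay, replacing one directly attached ring with another produces the largest step seen so far in this small set, an 8.6-fold higher number from compound 3 to compound 4 (0.94 log units; beyond the scatter), with no change in the link to the shared core. A directly attached ring therefore does not by itself give a low number: the 2-(4-fluorophenyl)ethenyl group does better than the 3-chlorophenyl, as shown by a 4.0-fold higher number from compound 2 to compound 4 (0.60 log units; beyond the scatter), while the 2-(3-(trifluoromethyl)phenyl)ethenyl group cannot be told apart from it, as shown by a 1.5-fold higher number from compound 1 to compound 4 (0.18 log units; within the scatter). So what is attached to the ring at this place counts for a great deal, although no measurement here explains the size of the effect.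

The exchange from 4-(dimethylamino)phenyl to 3-chlorophenyl alters both the substituent and where it sits on the ring, so the compounds shown cannot separate these two changes. From the compounds shown here alone, it also remains open how a plain phenyl ring, or a phenyl ring carrying a different amine such as morpholine, would compare at this place, and so whether an amine on the ring is what matters.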